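From Carbamoyl to Carboxy: One Step Ahead of Measurement

The source may report more compounds than this note shows. Statements on the series, on what has been measured and on what is new or still open speak of the compounds shown alone.

Compound 1, `O=C(CN(c1ncnc2c1ncn2C1CCCCO1)C1CC1)NCC(=O)OCc1ccccc1`, gives 40.4% in a functional assay on the whole organism (Tail, strain ICR) with Mus musculus as the target, in the tail flick test, with a stated time of 60 min, at a dose of 25 umol/kg by the oral route; on this read-out higher numbers stand for a stronger effect at the one dose given and lower numbers for a weaker effect.
Compound 2, `NC(=O)C[C@H](NC(=O)CN(c1nc(Cl)nc2[nH]cnc12)C1CC1)C(=O)O`, gives 43.1%.
Compound 3, `O=C(CN(c1ncnc2c1ncn2C1CCCCO1)C1CC1)N[C@@H](CO)C(=O)OCc1ccccc1`, gives 46.7%.

Of the compounds shown here, three have been measured, and their numbers lie close together. Compound 2 stands with compound 1 on one side and compound 3 on the other, and its gap to either is within the usual scatter, so the three cannot be told apart on these numbers. Within the data shown here, the only single-point step among them, a number 6.3 percentage points higher from compound 1 to compound 3 (within the scatter), is likewise within the scatter.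

Compound 4, `O=C(O)C[C@H](NC(=O)CN(c1nc(Cl)nc2[nH]cnc12)C1CC1)C(=O)O`, has not yet been measured. It differs from compound 2 in one place: hydroxy in place of amino on a carbonyl carbon. Among the measured compounds shown here, no measured pair shows this kind of change, so nothing in the data speaks directly to it. For the measured compounds named here, the one step that has been measured, from compound 1 to compound 3, concerns a different part of the molecule and in any case stayed within the scatter.

Going by the values given here, with no step bearing on the change, and all three measured compounds sitting in one narrow band, the expectation for compound 4 is a value in that same band, and the step of a number 2.1 percentage points lower from compound 2 to compound 4 (within the scatter) is expected to stay within the scatter. Compound 4 is therefore estimated at 41%, with a range from 26% to 56%.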

Compound 4, a percentage reported as activity, at one dose (the size of the read-out at that dose, not a potency): 38.9%
Beside the measured number, compound 4's estimate is 2.1 percentage points above it; measured number inside the range.
By their numbers in this assay, from the lowest: compounds 4, 1, 2 and 3 (each within the scatter of the next).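

In this assay, the change from carbamoyl to carboxy gives a number 4.2 percentage points lower from compound 2 to compound 4 (within the scatter), so the carbonyl carbon whose other neighbour is a saturated chain carbon now has a measured step of its own, and that step does not separate the two compounds. Among these compounds, the earlier compounds held no pair that differed at this place, and their only step, a number 6.3 percentage points higher from compound 1 to compound 3 (within the scatter), concerned a saturated chain carbon bound to an amide-type nitrogen and a carbonyl carbon; the two single-place changes now on record both stay within the scatter on this read-out. Nothing available explains why hydroxy in place of amino leaves the two compounds inseparable here, and the result has to stand without an explanation.

Going by these compounds, it remains open whether other groups on this carbonyl carbon, such as a methyl ester or a hydroxamic acid, or a longer chain ending in a carboxylic acid in place of carboxymethyl, would move the read-out beyond the scatter. Each compound is also shown at a single dose and a single time, so any difference in potency or time course between compound 2 and compound 4 stays undecided.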